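This account rests on a few compounds, and the source may have more. Where it says the series, first, only, none or still open, it means among the compounds named here.

Two compounds have been characterised in an assay on CHO cells for displacement of a labelled ligand from C-X-C chemokine receptor type 3 (Homo sapiens), with a stated time of 60 min; a lower number here means a stronger inhibitor, a higher number a weaker inhibitor. Compound 1 `Cc1cc(CN(CC2CCCC2)C(CC(=O)O)c2ccc(Cl)cc2)ccc1OCCN1C(=O)CCC1=O` gives 71 nM in this assay. Compound 2 `Cc1cc(CN(C)C(CC(=O)O)c2ccc(Cl)cc2)ccc1OCCn1c(=O)ccn(C)c1=O`, which carries a methyl on the amine nitrogen and a different tail on the ether, gives 1300 nM in this assay, the higher of the two numbers; the gap between compound 2 and compound 1 lies well beyond the usual scatter, but the two structures differ in more than one place, so no single change can be credited.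

Compound 3 `Cc1cc(CN(CC2CC2)C(CC(=O)O)c2ccc(Cl)cc2)ccc1OCCn1c(=O)ccn(C)c1=O` keeps the core and tail of compound 2 and differs from it only in one place: cyclopropyl in place of hydrogen on a saturated chain carbon bound to an amine nitrogen. Compound 3 has not yet been measured in this assay. Since compound 1, with a larger ring on the same nitrogen, gives 71 nM, a step toward a lower number is expected, though of uncertain size; the expected step is a 5.2-fold lower number from compound 2 to compound 3 (0.72 log units; beyond the scatter). Compound 3 is accordingly estimated at 250 nM, within a range of 80 nM to 800 nM.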

Compound 3, half-maximal inhibitory concentration: 91 nM
Compound 3: the middle estimate sits 2.7-fold (0.44 log units) above what was measured, and the stated range covers the measured number.
By their numbers in this assay, from the lowest: compounds 1 and 3 (each within the scatter of the next); then compound 2.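

With the core and tail of compound 2 held fixed, the group on the amine nitrogen now has a measured effect of its own: in this assay the change from methyl to cyclopropylmethyl gives a 14-fold lower number from compound 2 to compound 3 (1.15 log units; beyond the scatter) and so the position clearly responds to this change. The earlier pair could not show this, as its two members also differ in the tail on the ether. No measurement shown gives a reason for the size of this step.

As far as these compounds go, whether the ring itself matters remains open, as an ethyl group or a longer unbranched chain on this nitrogen would be needed to separate the ring from simple chain length. From the compounds shown here alone, whether the same change gives a step of similar size with the tail of compound 1 also remains open.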